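The source may report more compounds than this note shows. Statements on the series, on what has been measured and on what is new or still open speak of the compounds shown alone.

In an assay on isolated protein for activation of cGMP-dependent protein kinase 1 (Homo sapiens), read by ADP-Glo, with stated times of 30 min and 2 h, in the presence of a further agent that is not named here (a higher number here means that more compound is needed for the effect, a lower number that less compound is needed), compound 3 `Cc1cc(C(=O)O)ccc1CN1CCC[C@H](O[C@H](CO)c2cc(F)cc(F)c2)[C@@H]1c1ccccc1` gives 1500 nM, the lowest of the three numbers in hand. Compound 2 `Cc1cc(C(=O)O)ccc1CN1CCC[C@H](O[C@H](CO)c2ccccc2)[C@@H]1c1ccccc1` gives 25000 nM, and compound 1 `COc1cccc([C@@H](CO)O[C@H]2CCCN(Cc3ccc(C(=O)O)cc3C)[C@H]2c2ccccc2)c1` gives 81000 nM. The step of a 3.2-fold lower number from compound 1 to compound 2 (0.51 log units; beyond the scatter) is modest, whereas a 54-fold lower number from compound 1 to compound 3 (1.73 log units; beyond the scatter) and a 17-fold lower number from compound 2 to compound 3 (1.22 log units; beyond the scatter) are both large, so among these three compounds the aromatic ring on the saturated chain carbon bound to an oxygen on a saturated carbon has moved the number strongly. Compound 4 `Cc1cc(C(=O)O)ccc1CN1CCC[C@H](O[C@H](CF)c2cc(Cl)cc(Cl)c2)[C@@H]1c1ccccc1` carries a group of 11 heavy atoms (8 carbon, 1 fluorine, 2 chlorine; one six-membered aromatic ring of carbon only) in place of a group of 11 heavy atoms (8 carbon, 1 oxygen, 2 fluorine; one six-membered aromatic ring of carbon only), on an oxygen on a saturated carbon. For the measured compounds named here, no measured step covers this change as a whole: the two large steps ending at compound 3 concern only the aromatic ring, while the move to compound 4 also removes the single hydrogen-bond donor and acceptor counted in the group that leaves, for which nothing has been measured. The size of the ring steps and the unmeasured chain change together call for a wide range. Compound 4 is therefore estimated at 2000 nM, with a range from 400 nM to 10000 nM. The implied step a 1.3-fold higher number from compound 3 to compound 4 (0.12 log units; within the scatter) is expected to remain within the scatter.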

Compound 4, half-maximal effective concentration: 9100 nM
Compound 4: middle estimate off by 4.6-fold (0.66 log units), on the low side; the range from low to high includes it.
By their numbers in this assay, from the lowest: compound 3; then compound 4; then compound 2; then compound 1.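

In this assay, for the compounds shown here, exchanging the whole group on an oxygen on a saturated carbon gives a 6.1-fold higher number from compound 3 to compound 4 (0.78 log units; beyond the scatter), so this change gives back part of the ground gained in the ring steps without returning the number to that of the earlier compounds. The same group still keeps a 2.7-fold lower number from compound 2 to compound 4 (0.44 log units; beyond the scatter) and an 8.9-fold lower number from compound 1 to compound 4 (0.95 log units; beyond the scatter), which shows that at this place a group with 0 hydrogen-bond donors and 0 hydrogen-bond acceptors can still give a lower number than the phenyl and 3-methoxyphenyl groups do. Nothing available explains these shifts.

The aromatic ring and the chain differ together in compound 4, so the compounds shown do not separate the share of each in the step. On these data alone, how an amine or a longer chain would behave on the saturated chain carbon remains open.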